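This account rests on a few compounds, and the source may have more. Where it says the series, first, only, none or still open, it means among the compounds named here.

Measured in a functional assay on HeLa cells (Homo sapiens) for cytotoxicity, read by WST assay, with a stated time of 48 h; a lower number here means a stronger inhibitor, a higher number a weaker inhibitor:
Compound 1 `COc1cc(C(c2ccc(O)c(OC)c2)[C@H](C)[C@H](C)CO)ccc1O`: > 100000 nM, a limit
Compound 2 `COC[C@@H](C(C)C)C(c1ccc(O)c(OC)c1)c1ccc(O)c(OC)c1`: 69000 nM
Compound 3 `COc1cc(C(c2ccc(O)c(OC)c2)[C@@H](C)[C@H](C)CO)ccc1O`: > 100000 nM, a limit

In this assay compound 3 gives > 100000 nM, which is a limit of the assay and not a number. It therefore sits at the limit of > 100000 nM in this assay, at which 2 of the 3 values shown sit. Compound 4 `COc1cc(C(c2ccc(O)c(OC)c2)[C@@H](C)[C@H](C)CF)ccc1O` carries fluoro in place of hydroxy on a saturated chain carbon, four bonds along the chain from two aromatic carbons.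

For the measured compounds named here, no measured step makes this exchange. The closest are the swaps between the 2-(hydroxymethyl)-1-methylpropyl and 1-(methoxymethyl)-2-methylpropyl groups, an at least 1.4-fold lower number from compound 1 to compound 2 (0.16 log units; that floor lies within the scatter) and an at least 1.4-fold higher number from compound 2 to compound 3 (0.16 log units; that floor lies within the scatter). The change in configuration gives a step that the two limits leave unreadable from compound 1 to compound 3. None of these shows a size beyond the scatter, so only a small move towards a lower number is expected, or none beyond the scatter. Going by the values given here, compound 2, at 69000 nM, is the only measured number to anchor that expectation. The expected step is an at least 1.4-fold lower number from compound 3 to compound 4 (0.15 log units; that floor lies within the scatter). Compound 4 is estimated at 70000 nM, with an expected range from 20000 nM to 200000 nM.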

Compound 4, half-maximal inhibitory concentration: 37000 nM
The estimate for compound 4 lay 1.9-fold (0.28 log units) above the measured number; low and high end bracket the measured number.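

Fluoro in place of hydroxy on a saturated chain carbon, four bonds along the chain from two aromatic carbons, gives the first step at this position that lies beyond the scatter in this assay: an at least 2.7-fold lower number from compound 3 to compound 4 (0.43 log units; beyond the scatter). Set against the other configuration as drawn, the 2-(fluoromethyl)-1-methylpropyl group also gives a step beyond the scatter: an at least 2.7-fold lower number from compound 1 to compound 4 (0.43 log units; beyond the scatter). Against the 1-(methoxymethyl)-2-methylpropyl group, however, the step stays within the scatter, so the fluoro compound cannot be ranked apart from that ether: a 1.9-fold lower number from compound 2 to compound 4 (0.27 log units; within the scatter).

The compounds shown leave open whether fluoro in the configuration of compound 1 would give a similar number. They also leave open how an amine, a chloro group or a longer chain would read on this carbon.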